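This account rests on a few compounds, and the source may have more. Where it says the series, first, only, none or still open, it means among the compounds named here.

Measured in an ADME assay on HEK-293T cells (Homo sapiens) for cytotoxicity, read by CCK-8 assay, with a stated time of 48 h; on this read-out lower numbers stand for stronger inhibition and higher numbers for weaker inhibition:

compound 1, `COc1ccc(Oc2ccc(C(C)C)cc2-c2ccsc2S(=O)(=O)NCCNC(=S)Nc2ccc([N+](=O)[O-])cc2)cc1OC`: 11400 nM
compound 2, `COc1ccc(Oc2ccc(C(C)C)cc2-c2ccsc2S(=O)(=O)NCCNC(=O)Nc2cc(Cl)cc(Cl)c2)cc1OC`: 11900 nM
compound 3, `Cc1ccc(-c2ccsc2S(=O)(=O)NCCNC(=S)Nc2ccc([N+](=O)[O-])cc2)c(Oc2ccc(O)c(O)c2)c1`: 8200 nM

Compound 1 and compound 2 share one core and differ in a single place: a group of 11 heavy atoms (7 carbon, 1 nitrogen, 1 oxygen, 2 chlorine; one six-membered aromatic ring of carbon only) in place of a group of 12 heavy atoms (7 carbon, 2 nitrogen, 2 oxygen, 1 sulfur; one six-membered aromatic ring of carbon only), on an amine nitrogen. The step that this change made in this assay is a 1.0-fold higher number from compound 1 to compound 2 (0.02 log units; within the scatter), so on this read-out the two compounds are not told apart.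

Compound 3 sits on a different core, and the difference between the core of compound 1 and the core of compound 3 is not broken down here. Its value in this assay lies within the scatter of compound 1 and compound 2, so no ordering among the three measured compounds is claimed.

Compound 4, `Cc1ccc(-c2ccsc2S(=O)(=O)NCCNC(=O)Nc2cc(Cl)cc(Cl)c2)c(Oc2ccc(O)c(O)c2)c1`, is the counterpart of compound 3: it carries the same change as seen from compound 1 to compound 2, namely (a group of 11 heavy atoms (7 carbon, 1 nitrogen, 1 oxygen, 2 chlorine; one six-membered aromatic ring of carbon only) in place of a group of 12 heavy atoms (7 carbon, 2 nitrogen, 2 oxygen, 1 sulfur; one six-membered aromatic ring of carbon only), on an amine nitrogen), at a place described in the same words, an amine nitrogen whose other neighbours are a saturated chain carbon. Among the compounds with values here, the only precedent for this change is the pair compound 1 to compound 2, where it left the number essentially unchanged.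

On that basis the step from compound 3 to compound 4 in this assay is expected to be small, a 1.0-fold higher number from compound 3 to compound 4 (0.02 log units; within the scatter), resting on the flat step a 1.0-fold higher number from compound 1 to compound 2 (0.02 log units; within the scatter). Compound 4 is accordingly estimated at 8500 nM, with a likely range from 4500 nM to 16000 nM, the width reflecting that the change is backed by a single pair on another core.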

Compound 4, half-maximal inhibitory concentration: 6700 nM
For compound 4 the middle estimate is 1.3-fold (0.10 log units) above the measured one, within the range that was stated.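

In this assay, putting (3,5-dichlorophenyl)carbamoyl in place of the group that leaves, on an amine nitrogen whose other neighbours are a saturated chain carbon, gives a 1.2-fold lower number from compound 3 to compound 4 (0.09 log units; within the scatter). Set beside the earlier pair, the change reads alike on the two cores: the same change on two cores in this assay, a 1.0-fold higher number (0.02 log units; within the scatter) from compound 1 to compound 2 and a 1.2-fold lower number (0.09 log units; within the scatter) from compound 3 to compound 4, 1.3-fold (0.11 log units) apart, within the scatter of two such steps. Within the data shown here, this supports carrying the change between these two cores as a flat step on this cytotoxicity read-out, but it rests on only two pairs, neither of which leaves the scatter, and it shows neither that the step stays flat on any other core nor which part of the exchanged group matters, as the link and the ring substituents change together.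

The compounds shown leave open how each part of the change reads alone, for instance a urea link kept with a nitrophenyl ring, or a thiourea link kept with the 3,5-dichlorophenyl ring. Also open, as far as these compounds go, is whether the flat step holds with other groups at this place, such as a phenyl ring carrying an amine or a carboxylic acid, or with a longer chain on the sulfonamide nitrogen.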